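Trifluoromethoxy for carbamoyl in a series held at its limit

A few compounds are considered here, and "the series" means these few. Any claim that something is new, unique, unknown or untested is made for them only; others in the source may bear on it.

In an ADME assay on Raji cells (Homo sapiens) for cytotoxicity, with a stated time of 72 h (a higher number here means that more compound is needed for the effect, a lower number that less compound is needed), compound 1 (`CCc1ccc(NC(=O)Nc2cc(C)nc3ccccc23)cc1`) gives > 25000 nM as a limit of the assay. Compound 2 (`CC(=O)c1ccc(NC(=O)Nc2cc(C)nc3ccccc23)cc1`) gives > 25000 nM which is again a limit. Compound 3 (`Cc1cc(NC(=O)Nc2ccc(C(N)=O)cc2)c2ccccc2n1`) gives > 25000 nM and this too is a limit, not a number. Compound 3 therefore stands at the limit of > 25000 nM in this assay, at which 3 of the 3 values shown sit, with no number of its own.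

The next change leads to compound 4 (`Cc1cc(NC(=O)Nc2ccc(OC(F)(F)F)cc2)c2ccccc2n1`), with trifluoromethoxy in place of carbamoyl on an aromatic carbon. The measured steps that bear on it are a step that the two limits leave unreadable from compound 1 to compound 2 and a step that the two limits leave unreadable from compound 1 to compound 3 and a step that the two limits leave unreadable from compound 2 to compound 3 and none of them has a readable size. They set no size for the new step, and no direction. Compound 3 still reports > 25000 nM as a limit, so no step beyond the scatter is expected in this assay from this change. The expected change is a number no higher from compound 3 to compound 4 (the limit leaves the size open) by this estimate. Compound 4 is estimated at 25000 nM with an expected range from 8000 nM to 50000 nM and may well report only a limit.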

Compound 4, half-maximal effective concentration: 10000 nM
The estimate for compound 4 lay 2.5-fold (0.40 log units) above the measured number; the measured number falls inside the stated range.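

In this assay, going by these compounds alone, trifluoromethoxy on this aromatic carbon, para to a large group, gives in place of carbamoyl an at least 2.5-fold lower number from compound 3 to compound 4 (0.39 log units; beyond the scatter) and so provides the first reading that is a number. Set against the other two groups at this place, it gives an at least 2.5-fold lower number from compound 2 to compound 4 (0.39 log units; beyond the scatter) for acetyl and an at least 2.5-fold lower number from compound 1 to compound 4 (0.39 log units; beyond the scatter) for ethyl, so the lower number holds against all three groups shown. In this assay compound 4 alone has a number, and the other three compounds remain at a limit: the limit of > 25000 nM in this assay, at which 3 of the 4 values shown sit.

On these data alone, how far these three steps really run stays open, and the steps among compound 1, compound 2 and compound 3 cannot be read. Also open, as far as these compounds go, is whether a trifluoromethyl group, a chlorine atom or a longer chain at this place would give a number like that of compound 4, or whether an amine there would stay at the limit.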